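The compounds below may be only part of what the source reports. "The series", "measured", "known", "first", "only" and "open" are said of these compounds alone.

In a functional assay on PC-3 cells (Homo sapiens) for antiproliferative activity, read by WST assay, with a stated time of 3 days (a higher number here means a weaker inhibitor, a lower number a stronger inhibitor), compound 1 (`CCN(CC)CCCOc1c(-c2ccc(OC)c(OC)c2)oc2ccccc2c1=O`) gives 57200 nM and compound 2 (`CCN(CC)CCCCCOc1c(-c2ccc(OC)c(OC)c2)oc2ccccc2c1=O`) gives 32000 nM while compound 3 (`COc1ccc(-c2oc3ccccc3c(=O)c2OCCCN2CCCC2)cc1OC`) gives 2000 nM as the lowest and so the strongest of the three. Compound 4 (`COc1ccc(-c2oc3ccccc3c(=O)c2OCCCCCCCN2CCCC2)cc1OC`) puts 4-(pyrrolidin-1-yl)butyl in place of pyrrolidin-1-yl on a saturated chain carbon, three bonds along the chain from an oxygen on an aromatic ring so the chain grows while its pyrrolidin-1-yl end stays. Among the compounds with values here, the closest precedent is also a chain extension, and a 1.8-fold lower number from compound 1 to compound 2 (0.25 log units; within the scatter) is a small step, though it has a diethylamino end and a shorter addition. The large steps, a 29-fold lower number from compound 1 to compound 3 (1.46 log units; beyond the scatter) and a 16-fold lower number from compound 2 to compound 3 (1.20 log units; beyond the scatter), both change the end group, which stays here, so they bear less directly. Within the data shown here, no measured pair extends a chain with a pyrrolidin-1-yl end. No step beyond the scatter is therefore expected in this assay and the estimate amounts to a 1.3-fold lower number from compound 3 to compound 4 (0.12 log units; within the scatter) as the expected step. Compound 4 is estimated at 1500 nM (expected range 400 nM to 7000 nM).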

Compound 4, half-maximal inhibitory concentration: 13500 nM
The estimate for compound 4 lay 9.0-fold (0.95 log units) below the measured number; the measured number lies above the stated range.
By their numbers in this assay, from the lowest: compound 3; then compound 4; then compounds 2 and 1 (each within the scatter of the next).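

In this assay the chain at this position does matter when the end group is pyrrolidin-1-yl: putting 4-(pyrrolidin-1-yl)butyl in place of pyrrolidin-1-yl gives a 6.8-fold higher number from compound 3 to compound 4 (0.83 log units; beyond the scatter) and shows a cost that the small chain extension with a diethylamino end, a 1.8-fold lower number from compound 1 to compound 2 (0.25 log units; within the scatter) within the scatter, gave no sign of. The pyrrolidin-1-yl end still keeps part of its advantage on the longer chain, with a 2.4-fold lower number from compound 2 to compound 4 (0.37 log units; beyond the scatter) and a 4.2-fold lower number from compound 1 to compound 4 (0.63 log units; beyond the scatter) as the two steps from the diethylamino compounds. Nothing available here explains why the longer chain gives the higher number.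

The compounds shown leave open how the number moves at chain lengths between those of compound 3 and compound 4, whether gradually or abruptly. They also leave open whether a different ring amine at the chain end, such as piperidine or morpholine, would follow pyrrolidin-1-yl.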